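The source may hold more compounds than are shown below. What is called first, only, known or untested is meant among the compounds shown, and "the series" means these compounds.

Measured so far:
- compound 1, `Cc1ccncc1C(=O)N1CC(Oc2cncc(N3C(=O)c4ccc(Cl)cc4C3(C)C)c2)C1`, gives 10.4 mL/min/kg in an ADME assay on microsomes from liver (Rattus norvegicus) for metabolic stability, read by LC-MS, using NADPH, with stated times of 10 min and 30 min; on this read-out lower numbers stand for slow clearance and higher numbers for fast clearance.
- compound 2, `CC(=O)N[C@@H]1CCCc2c1cncc2N1CCc2cc(Cl)ccc2C1=O`, gives < 20.2 mL/min/kg in this assay; this is a limit of the assay, not a number.

Within the data shown here, compound 1 therefore stands as the only compound with a plain number in this assay; the one other value shown, for compound 2, is a limit. What the data offer on this point is the limit of < 20.2 mL/min/kg in this assay, at which 1 of the 2 values shown sits. Among the measured compounds shown here, no step between two measured compounds is available, since compound 1 and compound 2 differ in more than one place.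

Compound 3, `Cn1cc(C(=O)N2CC(Oc3cncc(N4C(=O)c5ccc(Cl)cc5C4(C)C)c3)C2)cn1`, has not yet been measured. It differs from compound 1 in one place: 1-methyl-1H-pyrazol-4-yl in place of 4-methylpyridin-3-yl on a carbonyl carbon. Both the group that leaves and the group that enters sit on a carbonyl carbon whose other neighbour is an amide-type nitrogen in a ring. For the measured compounds named here, with no measured step of this kind to lean on, the step from compound 1 to compound 3 is expected to stay within the usual scatter of this assay, with at most a slight lean toward slower clearance, as a 1.2-fold lower number from compound 1 to compound 3 (0.06 log units; within the scatter). For compound 3 the clearance in this assay is estimated at 9 mL/min/kg, with a range from 4 mL/min/kg to 22 mL/min/kg.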

Compound 3, clearance: 6.4 mL/min/kg
Beside the measured number, compound 3's estimate is 1.4-fold (0.15 log units) above it, and the stated range covers the measured number.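

Among these compounds, the exchange of 4-methylpyridin-3-yl for 1-methyl-1H-pyrazol-4-yl on a carbonyl carbon is the first step that can be read in this assay, and it gives a 1.6-fold lower number from compound 1 to compound 3 (0.21 log units; within the scatter). This place on the core of compound 1 can therefore carry either a six-membered aromatic ring with 1 hetero atom or a five-membered aromatic ring with 2 hetero atoms, and this read-out does not tell the two compounds apart, even though the ring size and the number of hydrogen-bond acceptors are not the same. Nothing shown here gives a reason for this outcome, so the step stands as an observation and not as an explanation.

As far as these compounds go, two aromatic rings are a narrow sample of what this place could hold, so it remains open whether an open-chain amine or a carboxylic acid on the same carbonyl carbon would read the same way in this assay. From the compounds shown here alone, it is also open whether the methyl group on each ring plays any part, and whether this exchange would read alike on a different core.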